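A few compounds are considered here, and "the series" means these few. Any claim that something is new, unique, unknown or untested is made for them only; others in the source may bear on it.

Measured so far in a functional assay on cells for antagonist activity at C-C chemokine receptor type 4 (Homo sapiens), read by GTPgammaS binding; on this read-out lower numbers stand for stronger inhibition and higher numbers for weaker inhibition:
- compound 1 `COc1nn(C)c2ncnc(NS(=O)(=O)c3cccc(Cl)c3Cl)c12`: 63.1 nM
- compound 2 `COc1nc(NS(=O)(=O)c2cccc(Cl)c2Cl)c2c(OC)nn(C)c2n1`: 794 nM
- compound 3 `COc1nn(C)c2nc(NC3COC3)nc(NS(=O)(=O)c3cccc(Cl)c3Cl)c12`: 10000 nM

Compound 1 gives the lowest number of the three, and both steps away from it lie beyond the scatter: a 13-fold higher number from compound 1 to compound 2 (1.10 log units; beyond the scatter) and a 160-fold higher number from compound 1 to compound 3 (2.20 log units; beyond the scatter). The step between the other two is also large, a 13-fold higher number from compound 2 to compound 3 (1.10 log units; beyond the scatter). All three measured steps change the same part of the shared core of compound 1; the sulfonamide side is held constant throughout.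

Compound 4 `COc1nn(C)c2ncnc(NS(=O)(=O)c3ccc(Cl)s3)c12` takes the other route. The change from compound 1 is 5-chlorothiophen-2-yl in place of 2,3-dichlorophenyl on a sulfonyl sulfur. For the measured compounds named here, no measured step touches the sulfonyl sulfur, so none of the three steps bears directly on this change; the measured series says only that compound 1 is the reference point and that the core tolerates little alteration. With no guidance on the sulfonyl side, the working assumption is a moderate change, if any, with the direction open, and the range kept wide to cover both outcomes.

On that basis compound 4 is expected to give about 160 nM, with a range from 40 nM to 700 nM. The expected step is a 2.5-fold higher number from compound 1 to compound 4 (0.40 log units; beyond the scatter).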

Compound 4, half-maximal inhibitory concentration: 79.4 nM
Compound 4: the middle estimate sits 2.0-fold (0.30 log units) above what was measured; the range from low to high includes it.
By their numbers in this assay, from the lowest: compounds 1 and 4 (each within the scatter of the next); then compound 2; then compound 3.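

In this assay, the place on the sulfonyl sulfur accepts 5-chlorothiophen-2-yl in place of 2,3-dichlorophenyl with only a 1.3-fold higher number from compound 1 to compound 4 (0.10 log units; within the scatter), so this assay does not separate the two groups. For the compounds shown here, this is the first measured change away from the shared core, and unlike the three large steps made on the core, it leaves the number within the scatter even though a five-membered aromatic ring with one hetero atom and one chlorine replaces a six-membered carbon ring with two chlorines. Nothing available explains why the two groups read alike.

A single exchange cannot show how far this tolerance extends: the compounds shown leave open whether a group outside the chlorinated aromatic rings, such as a plain alkyl chain, a benzyl group or a pyridine ring, would hold the number at this level. They also leave open whether chlorine is needed at all, which an unsubstituted phenyl or thiophen-2-yl on the sulfonyl sulfur would address.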